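Replacing 4-Methylphenyl with an Ester-Bearing Chain

A few compounds are considered here, and "the series" means these few. Any claim that something is new, unique, unknown or untested is made for them only; others in the source may bear on it.

Within the data shown here, compound 2 `C/C(=N\Nc1nc(-c2ccc(C)cc2)cs1)c1cc2ccccc2o1` gives 11100 nM in a functional assay on MCF7 cells (Homo sapiens) for antiproliferative activity (on this read-out higher numbers stand for weaker inhibition and lower numbers for stronger inhibition), the lowest of the two numbers measured so far; compound 1 `C/C(=N\Nc1nc(-c2ccc(Cl)cc2)cs1)c1cc2ccccc2o1` gives 29900 nM, and the only measured step is a 2.7-fold lower number from compound 1 to compound 2 (0.43 log units; beyond the scatter). Compound 3 `CCOC(=O)Cc1csc(N/N=C(\C)c2cc3ccccc3o2)n1` differs from compound 2 in one place: (ethoxycarbonyl)methyl in place of 4-methylphenyl on an aromatic carbon. Among the measured compounds shown here, no measured step bears on this change, which removes the six-membered aromatic ring altogether rather than altering a substituent on it. The expectation therefore rests on compound 2 alone and is uncertain. A modestly higher number is expected for compound 3, a 2.7-fold higher number from compound 2 to compound 3 (0.43 log units; beyond the scatter). The estimate for compound 3 is 30000 nM, within a range of 8000 nM to 100000 nM.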

Compound 3, half-maximal inhibitory concentration: 6550 nM
For compound 3 the middle estimate is 4.6-fold (0.66 log units) above the measured one; measured number outside the range, below it.
By their numbers in this assay, from the lowest: compounds 3 and 2 (each within the scatter of the next); then compound 1.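

In this assay, the aromatic ring at this position can be lost without a change beyond the scatter: a 1.7-fold lower number from compound 2 to compound 3 (0.23 log units; within the scatter) leaves (ethoxycarbonyl)methyl and 4-methylphenyl indistinguishable. The comparison with 4-chlorophenyl, a 4.6-fold lower number from compound 1 to compound 3 (0.66 log units; beyond the scatter), lies beyond the scatter, so a six-membered aromatic ring here is not required for a number at this level. No available evidence explains these results. As far as these compounds go, it remains open whether the ester matters, since a carboxylic acid, an amide or a longer chain on this carbon would test what this group contributes.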